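Fluoro in place of hydrogen on compound 3

A few compounds are considered here, and "the series" means these few. Any claim that something is new, unique, unknown or untested is made for them only; others in the source may bear on it.

Measured in a functional assay on MCF-10A cells (Homo sapiens) for antiproliferative activity, with a stated time of 48 h (on this read-out lower numbers stand for an effect already at smaller amounts and higher numbers for an effect only at larger amounts of compound), so far:
- compound 1 `COc1ccc2nc(C)cc(NCc3ccc(C)cc3)c2c1` gives 22400 nM
- compound 2 `COc1ccc2nc(C)cc(NCC3CCCN(C)C3)c2c1` gives 5800 nM
- compound 3 `COc1ccc2nc(C)cc(NCc3cccc(F)c3)c2c1` gives 14700 nM

Compound 3 stands with compound 1 at the high end of these numbers, as a 1.5-fold lower number from compound 1 to compound 3 (0.18 log units; within the scatter) shows. It is set apart from compound 2 by a 2.5-fold higher number from compound 2 to compound 3 (0.40 log units; beyond the scatter) in the same read-out.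

The next structure is compound 4 `COc1ccc2nc(C)cc(NCc3ccc(F)c(F)c3)c2c1` and the change is fluoro in place of hydrogen on an aromatic carbon with fluoro in place of hydrogen on an aromatic carbon, ortho to a fluoro group and para to a large group.

For the measured compounds named here, no measured step tests this exact change. The nearest evidence is a 1.5-fold lower number from compound 1 to compound 3 (0.18 log units; within the scatter) where one substituted phenyl group replaces another. The two modest steps, a 3.9-fold lower number from compound 1 to compound 2 (0.59 log units; beyond the scatter) and a 2.5-fold higher number from compound 2 to compound 3 (0.40 log units; beyond the scatter) both exchange a phenyl group for 1-methylpiperidin-3-yl or the reverse, a much larger edit, and so bear little on a single added fluoro.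

In this assay no shift beyond the scatter is therefore expected, and the estimated 1.2-fold lower number from compound 3 to compound 4 (0.07 log units; within the scatter) carries no firm direction. For compound 4 the expected value is 12500 nM within an estimated range of 6000 nM to 26000 nM for now.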

Compound 4, half-maximal effective concentration: 12000 nM
Compound 4: middle estimate off by 1.0-fold (0.02 log units), on the high side; the measured number falls inside the stated range.
By their numbers in this assay, from the lowest: compound 2; then compounds 4, 3 and 1 (each within the scatter of the next).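

In this assay fluoro in place of hydrogen on the aromatic carbon, ortho to a fluoro group and para to a large group, leaves the number within the scatter (a 1.2-fold lower number from compound 3 to compound 4 (0.09 log units; within the scatter)). For the compounds shown here, the earlier steps exchanged whole groups on the saturated chain carbon, whereas this is the first step here that changes one aromatic carbon and keeps the rest of compound 3 intact, and a second fluoro on the phenyl group produces no shift that can be read as a change in either direction. Nothing at hand accounts for this flat result.

The compounds shown test only fluoro at this position, so it remains open whether an amine, a carboxylic acid or a nitrile on the same aromatic carbon would move the number beyond the scatter. Going by these compounds alone, also open is whether any substituent on the phenyl group can close the gap to the 1-methylpiperidin-3-yl group, which so far is the only change to give a step beyond the scatter (a 2.5-fold higher number from compound 2 to compound 3 (0.40 log units; beyond the scatter)).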